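Swapping a thiophene for a thiazole at the alkyne tip

The source may report more compounds than this note shows. Statements on the series, on what has been measured and on what is new or still open speak of the compounds shown alone.

Compounds measured in an assay on CHO cells for displacement of a labelled ligand from adenosine receptor A3 (Homo sapiens), read by scintillation counting, with a stated time of 60 min; a lower number here means a stronger inhibitor, a higher number a weaker inhibitor:
Compound 1, `CNC(=O)[C@@]12C[C@@H]1[C@@H](n1cnc3c(NC)nc(C#Cc4ccccc4OC)nc31)[C@H](O)[C@@H]2O`: compound 1 gives 0.77 nM
Compound 2, `CNC(=O)[C@@]12C[C@@H]1[C@@H](n1cnc3c(NC)nc(C#Cc4cc5ccccc5o4)nc31)[C@H](O)[C@@H]2O`: compound 2 gives 1.62 nM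
Compound 3, `CNC(=O)[C@@]12C[C@@H]1[C@@H](n1cnc3c(NC)nc(C#Cc4ccsc4)nc31)[C@H](O)[C@@H]2O`: compound 3 gives 0.52 nM

Compound 3 has the lowest number of the three, but one of its two gaps is covered by the scatter, a 1.5-fold lower number from compound 1 to compound 3 (0.17 log units; within the scatter), while the other is not, a 3.1-fold lower number from compound 2 to compound 3 (0.49 log units; beyond the scatter). Among the measured compounds shown here, only the step to compound 2 separates compound 3 from another measured compound.

Compound 4, `CNC(=O)[C@@]12C[C@@H]1[C@@H](n1cnc3c(NC)nc(C#Cc4nccs4)nc31)[C@H](O)[C@@H]2O`, differs from compound 3 by 1,3-thiazol-2-yl in place of thiophen-3-yl on a triple-bonded carbon; cut one bond further out, the change reads 2-(thiophen-3-yl)ethynyl to 2-(1,3-thiazol-2-yl)ethynyl. For the measured compounds named here, no measured step exchanges one five-membered ring for another. The nearest comparisons are the exchange of 2-methoxyphenyl for thiophen-3-yl, a 1.5-fold lower number from compound 1 to compound 3 (0.17 log units; within the scatter), and of 1-benzofuran-2-yl for thiophen-3-yl, a 3.1-fold lower number from compound 2 to compound 3 (0.49 log units; beyond the scatter), both small. A step of similar size, within or just beyond the scatter, is therefore expected in this assay, with the direction uncertain. Compound 4 is estimated at 0.8 nM, between 0.3 nM and 2.5 nM, a step of a 1.5-fold higher number from compound 3 to compound 4 (0.19 log units; within the scatter).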

Compound 4, inhibition constant: 2.1 nM
For compound 4 the middle estimate is 2.6-fold (0.42 log units) below the measured one, and the stated range covers the measured number.
By their numbers in this assay, from the lowest: compounds 3 and 1 (each within the scatter of the next); then compounds 2 and 4 (each within the scatter of the next).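

In this assay, the position on the triple-bonded carbon proves sensitive even to an exchange of one five-membered aromatic ring for another with the same count of heavy atoms, with a 4.0-fold higher number from compound 3 to compound 4 (0.61 log units; beyond the scatter). The entering 1,3-thiazol-2-yl carries one more hetero atom and one more hydrogen-bond acceptor than thiophen-3-yl, and that difference alone separates the two compounds by more than the scatter. The new compound cannot be told apart from the benzofuran compound, with a 1.3-fold higher number from compound 2 to compound 4 (0.11 log units; within the scatter), but stands apart from the methoxyphenyl compound, with a 2.7-fold higher number from compound 1 to compound 4 (0.44 log units; beyond the scatter).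

The compounds shown leave open whether the step follows from the added ring nitrogen or from the changed point of attachment, a question that thiophen-2-yl or 1,3-thiazol-4-yl at this position would address. Nothing available here accounts for the size of the step.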